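The source may hold more compounds than are shown below. What is called first, only, known or untested is meant among the compounds shown, and "the series" means these compounds.

Measured so far in a functional assay on SW480 cells (Homo sapiens) for cytotoxicity, read by MTT assay, with a stated time of 4 days; a higher number here means a weaker inhibitor, a lower number a stronger inhibitor:
- compound 1 `C=C1C[C@]23C[C@@]1(O)CC[C@H]2c1ccc(O)c(C)c1[C@@H]3Cn1cc(-c2ccc(C(F)(F)F)cc2)nn1` gives > 20000 nM, a limit of the assay.
- compound 2 `C=C1C[C@]23C[C@@]1(O)CC[C@H]2c1ccc(OS(=O)(=O)c2ccc(C)cc2)c(C)c1[C@@H]3Cn1cc(-c2ccc(C)cc2)nn1` gives > 20000 nM, a limit of the assay.
- compound 3 `C=C1C[C@]23C[C@@]1(O)CC[C@H]2c1ccc(OS(=O)(=O)c2ccc(C)cc2)c(C)c1[C@@H]3Cn1cc(-c2ccc(F)cc2)nn1` gives > 20000 nM, a limit of the assay.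

Compound 3 stands at the limit of this assay, as do both other measured compounds (the limit of > 20000 nM in this assay, at which 3 of the 3 values shown sit). For the measured compounds named here, none of the values here is a number, so no compound can be ranked against another.

Going by the values given here, the one measured step that changes a single place, from compound 2 to compound 3, is a step that the two limits leave unreadable from compound 2 to compound 3; both ends sit at the limit, so its size is not readable.

The step to compound 4 `C=C1C[C@]23C[C@@]1(O)CC[C@H]2c1ccc(O)c(C)c1[C@@H]3Cn1cc(-c2ccc(F)cc2)nn1` is hydrogen in place of (4-methylphenyl)sulfonyl on an oxygen on an aromatic ring, that is, ((4-methylphenyl)sulfonyl)oxy to hydroxy. Among the compounds with values here, no measured step covers this change. What can be said is that compound 1, which already carries the free hydroxy on the same core, stands at the limit (the limit of > 20000 nM in this assay, at which 3 of the 3 values shown sit), and compound 3, the sulfonylated parent of compound 4, stands there too. The step from compound 3 to compound 4 is therefore expected to be a step that the limit leaves unreadable from compound 3 to compound 4, with no change beyond the scatter that can be foreseen.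

Compound 4 is expected to give 30000 nM in this assay, within the range 12000 nM to 100000 nM, most likely again as a limit rather than a number.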

Compound 4, half-maximal inhibitory concentration: > 20000 nM
Compound 4 ended at the assay's limit (the forecaster's own chance of this, stated with the estimate: 85%); the middle value lies beyond the limit too.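

In this assay compound 4 gives > 20000 nM, which is a limit and not a number. No new step can be read for compound 4 against compound 3 or compound 1, because both ends of each pair sit at the limit: the limit of > 20000 nM in this assay, at which 4 of the 4 values shown sit.

The compounds shown leave open what either change does to the read-out in this assay.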